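Ethylsulfonyl in place of methylsulfonyl on compound 2

This account rests on a few compounds, and the source may have more. Where it says the series, first, only, none or still open, it means among the compounds named here.

In an ADME assay on the whole organism (plasma) for pharmacokinetics, with Rattus norvegicus as the target, with a stated time of 24 h, at a dose of 10 mg/kg by the oral route (a higher number here means more compound in the circulation at the dose given, a lower number less compound in the circulation), compound 1 (`CCS(=O)(=O)NC(=O)c1c(-c2ccc[nH]c2=O)c2cc(C)ccc2n1Cc1cc(F)ccc1F`) gives 5340 ng.h/mL and compound 2 (`CCc1ccc2c(c1)c(-c1ccc[nH]c1=O)c(C(=O)NS(C)(=O)=O)n2Cc1cc(F)ccc1F`) gives 35000 ng.h/mL, the higher of the two numbers and beyond the scatter. Compound 3 (`CCc1ccc2c(c1)c(-c1ccc[nH]c1=O)c(C(=O)NS(=O)(=O)CC)n2Cc1cc(F)ccc1F`) has methyl in place of hydrogen on a saturated chain carbon bound to a sulfonyl sulfur, methylsulfonyl to ethylsulfonyl (methyl in place of hydrogen on a saturated chain carbon bound to a sulfonyl sulfur). Among the measured compounds shown here, no measured step isolates this change. A moderate fall in this assay is expected, as the ethylsulfonyl compound 1 stands at 5340 ng.h/mL, though compound 1 also differs elsewhere. The estimated change is a 2.2-fold lower number from compound 2 to compound 3 (0.34 log units; beyond the scatter). Compound 3 is expected at 16000 ng.h/mL, with a range of 5000 ng.h/mL to 45000 ng.h/mL.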

Compound 3, area under the concentration-time curve: 2300 ng.h/mL
For compound 3 the middle estimate is 7.0-fold (0.84 log units) above the measured one, and the stated range ends above it.
By their numbers in this assay, from the lowest: compound 3; then compound 1; then compound 2.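

In this assay, methylsulfonyl to ethylsulfonyl alone gives a large fall (a 15-fold lower number from compound 2 to compound 3 (1.18 log units; beyond the scatter)), so this saturated chain carbon bound to a sulfonyl sulfur tolerates one added methyl poorly. With ethylsulfonyl held constant, methyl in place of hydrogen on a saturated chain carbon bound to an aromatic carbon gives a modest fall (a 2.3-fold lower number from compound 1 to compound 3 (0.37 log units; beyond the scatter)), which is the smaller of the two steps. No data shown bear on the reason for either step. Open, from the compounds shown here alone, is how a propyl chain or a cyclopropyl ring on the sulfonyl sulfur would stand. Also open, going by these compounds, is whether the step holds on the core of compound 1.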